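Aryl exchange repeated on a second core

The source may report more compounds than this note shows. Statements on the series, on what has been measured and on what is new or still open speak of the compounds shown alone.

Measured in a functional assay on MCF7 cells (Homo sapiens) for cytotoxicity, read by MTT assay, with a stated time of 72 h; on this read-out higher numbers stand for weaker inhibition and lower numbers for stronger inhibition:
compound 1 `COc1ccc(/C=C2\S/C(=N\c3csc(-c4ccc(Cl)cc4)c3)NC2=O)cc1` gives 1000 nM
compound 2 `O=C1N/C(=N/c2csc(-c3ccc(Cl)cc3)c2)S/C1=C\c1ccc2ccccc2c1` gives 1200 nM
compound 3 `COc1ccc(/C=C2\S/C(=N\c3nc(-c4ccc(Cl)cc4)cs3)NC2=O)cc1` gives 100 nM

Compound 3 shows the lowest number of the three, its gaps to compound 1 and compound 2 both lying beyond the scatter, so it is the most potent measured member. Compound 1 and compound 2 lie within the scatter of each other. The change naphthalen-2-yl in place of 4-methoxyphenyl on a double-bonded chain carbon bound to a double-bonded ring carbon produced a 1.2-fold higher number from compound 1 to compound 2 (0.08 log units; within the scatter). The difference between the core of compound 1 and the core of compound 3 is not broken down here.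

Compound 4 `O=C1N/C(=N/c2nc(-c3ccc(Cl)cc3)cs2)S/C1=C\c1ccc2ccccc2c1` carries the same change on the core of compound 3: naphthalen-2-yl in place of 4-methoxyphenyl on a double-bonded chain carbon bound to a double-bonded ring carbon. Because the earlier instance gave a 1.2-fold higher number from compound 1 to compound 2 (0.08 log units; within the scatter), the step in this assay is expected to be small, a 1.2-fold higher number from compound 3 to compound 4 (0.08 log units; within the scatter), resting on that single precedent. Compound 4 is therefore estimated at 120 nM, expected between 50 nM and 300 nM.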

Compound 4, half-maximal inhibitory concentration: 300 nM
Estimate against measurement, compound 4: 2.5-fold (0.40 log units) below, within the range that was stated.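

On the core of compound 3, naphthalen-2-yl in place of 4-methoxyphenyl gave a 3.0-fold higher number from compound 3 to compound 4 (0.48 log units; beyond the scatter) in this assay. Set beside the same change on the core of compound 1, the two steps cannot be told apart: the same change on two cores in this assay, a 1.2-fold higher number (0.08 log units; within the scatter) from compound 1 to compound 2 and a 3.0-fold higher number (0.48 log units; beyond the scatter) from compound 3 to compound 4, 2.5-fold (0.40 log units) apart, within the scatter of two such steps. This fits a change that carries across these two cores with little dependence on the core, but two pairs neither prove that the steps are equal nor predict the step on any further core.

Still open, on these data alone, is how an amine, a carboxylic acid or a longer chain would read in place of 4-methoxyphenyl on a double-bonded chain carbon bound to a double-bonded ring carbon. Also open, as far as these compounds go, is whether any such group would give a lower number than compound 3 on its core.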